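Swapping a Sulfonyl Link for a Small Acyl Group

The compounds below may be only part of what the source reports. "The series", "measured", "known", "first", "only" and "open" are said of these compounds alone.

Within the data shown here, compound 2 `CC(C)C(NS(=O)(=O)Cc1ccccc1)C(=O)N1CCC(c2ccc(Cl)cc2)CC1` gives 303 nM in an assay on THP-1 cells for displacement of a labelled ligand from C-C chemokine receptor type 1 (Homo sapiens) (a lower number here means a stronger inhibitor, a higher number a weaker inhibitor), the highest of the three numbers measured so far. Among the measured compounds shown here, compound 1 `CC(C)CCC(=O)N[C@@H](C(=O)N1CCC(c2ccc(Cl)cc2)CC1)C(C)C` gives 26 nM and compound 3 `Cc1ccc(CCC(=O)N[C@@H](C(=O)N2CCC(c3ccc(Cl)cc3)CC2)C(C)C)cc1` gives 105 nM; the only single-point step among them, a 4.0-fold higher number from compound 1 to compound 3 (0.61 log units; beyond the scatter), is modest. Compound 4 `CC(C)C(=O)NC(C(=O)N1CCC(c2ccc(Cl)cc2)CC1)C(C)C` differs from compound 2 by isopropylcarbonyl in place of benzylsulfonyl on an amine nitrogen. For the measured compounds named here, no measured step covers this exact exchange, and compound 4 carries a shorter chain than compound 1. Still, because compound 1 gives 26 nM and compound 3 gives 105 nM with a carbonyl on that nitrogen, compound 4 is expected to show a lower number, a step of about a 3.8-fold lower number from compound 2 to compound 4 (0.58 log units; beyond the scatter). Compound 4 is therefore estimated at 80 nM, within 25 nM to 300 nM.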

Compound 4, half-maximal inhibitory concentration: 388 nM
The estimate for compound 4 lay 4.9-fold (0.69 log units) below the measured number; measured number outside the range, above it.
By their numbers in this assay, from the lowest: compound 1; then compound 3; then compounds 2 and 4 (each within the scatter of the next).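

On this amine nitrogen, isopropylcarbonyl in place of benzylsulfonyl gives a 1.3-fold higher number from compound 2 to compound 4 (0.11 log units; within the scatter) even though the entering group has no ring and fewer heavy atoms. A carbonyl on that nitrogen is therefore not enough on its own in this assay, where compound 1 gives 26 nM with a longer chain on the same carbonyl. No measurement shown explains this result.

From the compounds shown here alone, the link and the group attached to it changed together, so their separate contributions stay open. Isopropylsulfonyl or benzylcarbonyl on that nitrogen would separate them.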